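The source may report more compounds than this note shows. Statements on the series, on what has been measured and on what is new or still open speak of the compounds shown alone.

For the measured compounds named here, compound 2 `COc1ccc(-c2cc3[nH]nc(-c4cc(OC)c(OC)c(OC)c4)n3n2)cc1[N+](=O)[O-]` is one of two compounds measured so far: in a functional assay on HT-1080 cells (Homo sapiens) for antiproliferative activity, read by MTT assay, with a stated time of 72 h (a lower number here means a stronger inhibitor, a higher number a weaker inhibitor), compound 2 gives 35600 nM, and compound 1 `COc1ccc(-c2cc3[nH]nc(-c4cc(OC)c(OC)c(OC)c4)n3n2)cc1` gives 26500 nM, the two within the scatter of each other. Compound 3 `COc1ccc(-c2cc3[nH]nc(-c4cc(OC)c(OC)c(OC)c4)n3n2)cc1N` carries amino in place of nitro on an aromatic carbon. Going by the values given here, the only measured step that bears on this change is a 1.3-fold higher number from compound 1 to compound 2 (0.13 log units; within the scatter), and because that step a 1.3-fold higher number from compound 1 to compound 2 (0.13 log units; within the scatter) stayed within the scatter, little movement in either direction is expected here. Compound 3 is therefore estimated to give 30000 nM, with a likely range from 12000 nM to 80000 nM. The expected step of a 1.2-fold lower number from compound 2 to compound 3 (0.07 log units; within the scatter) would thus lie within the scatter.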

Compound 3, half-maximal inhibitory concentration: 17800 nM
Beside the measured number, compound 3's estimate is 1.7-fold (0.23 log units) above it, within the range that was stated.
By their numbers in this assay, from the lowest: compounds 3, 1 and 2 (each within the scatter of the next).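

At this position, ortho to a methoxy group, in this assay amino in place of nitro gives a 2.0-fold lower number from compound 2 to compound 3 (0.30 log units; within the scatter), and amino in place of hydrogen gives a 1.5-fold lower number from compound 1 to compound 3 (0.17 log units; within the scatter). Hydrogen, nitro and amino on this carbon therefore all lie within the scatter of one another, so none of the three stands apart. Nothing at hand explains this result. Still open, as far as these compounds go, is whether an acetamide or a carboxylic acid on this carbon would give a step beyond the scatter.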